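Bromo in place of trifluoromethyl in the series

This account rests on a few compounds, and the source may have more. Where it says the series, first, only, none or still open, it means among the compounds named here.

Values in a functional assay on SW-620 cells (Homo sapiens) for cytotoxicity, read by MTT assay, with stated times of 4 h and 72 h, tested at 2 uM; on this read-out higher numbers stand for weaker inhibition and lower numbers for stronger inhibition:
- compound 1 `Cc1cc(Nc2ccc(C(=O)/C=C/c3ccc(F)cc3)cc2)n2nc(SCc3nc4ccccc4[nH]3)nc2n1`: 85 nM
- compound 2 `Cc1cc(Nc2ccc(C(=O)/C=C/c3ccc4ccccc4c3)cc2)n2nc(SC(=O)c3csc4ccc(Cl)cc34)nc2n1`: 35 nM
- compound 3 `Cc1cc(Nc2ccc(C(=O)/C=C/c3ccc(C(F)(F)F)cc3)cc2)n2nc(SCc3nc4ccccc4[nH]3)nc2n1`: 1850 nM

Among these three, compound 3 stands highest at 1850 nM, and so is the weakest, clearly apart from both others in this assay. The next structure is compound 4 `Cc1cc(Nc2ccc(C(=O)/C=C/c3ccc(Br)cc3)cc2)n2nc(SCc3nc4ccccc4[nH]3)nc2n1`, which differs from it as follows: bromo in place of trifluoromethyl on an aromatic carbon. This is bromo in place of trifluoromethyl on an aromatic carbon, para to a large group.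

Within the data shown here, one measured step bears directly on this position: a 22-fold higher number from compound 1 to compound 3 (1.34 log units; beyond the scatter), large and beyond the scatter, with trifluoromethyl in place of fluoro on an aromatic carbon. Compound 2 differs from the others in more than one place, so its 35 nM gives no direct guide here. Among the measured compounds shown here, with compound 4, trifluoromethyl leaves and a halogen returns, as in compound 1, but bromo is not fluoro, and no bromo compound has a measured value yet. Part of that large step, not all of it, is therefore expected to be recovered. The expected change is a 5.3-fold lower number from compound 3 to compound 4 (0.72 log units; beyond the scatter), towards a lower number and beyond the scatter. For compound 4 the estimated value is 350 nM, with an expected range from 90 nM to 1400 nM.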

Compound 4, half-maximal inhibitory concentration: 290 nM
For compound 4 the middle estimate is 1.2-fold (0.08 log units) above the measured one; the measured number falls inside the stated range.
By their numbers in this assay, from the lowest: compound 2; then compound 1; then compound 4; then compound 3.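

In this assay, the change on this aromatic carbon, para to a large group, gives a 6.4-fold lower number from compound 3 to compound 4 (0.80 log units; beyond the scatter), so the loss seen with trifluoromethyl does not extend to every replacement of fluoro at this position. Bromo still does not match fluoro, with a 3.4-fold higher number from compound 1 to compound 4 (0.53 log units; beyond the scatter), which places the three groups in the order fluoro, bromo, trifluoromethyl from lowest to highest number, with each step beyond the scatter and the two halogens clearly separated. No measurement shown here explains this order.

Going by these compounds, with only these three groups compared directly, it remains open where chloro, methyl, methoxy or an amine at this position would fall relative to fluoro, bromo and trifluoromethyl. Among these compounds, compound 2 differs from the others in more than one place, so it also remains open whether the same order would hold with the sulfur-linked group of compound 2 in place of the one shared by compound 1, compound 3 and compound 4.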